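Chain extension on the shared core: cytotoxicity notes

The source may hold more compounds than are shown below. What is called first, only, known or untested is meant among the compounds shown, and "the series" means these compounds.

Compound 1 `CCCCCCc1cc2cn(COCCO)c(=O)nc2o1` is the reference point of this set. In a functional assay on HEL cells (Homo sapiens), read by microscopy (a higher number here means that more compound is tolerated, a lower number that less compound is tolerated), compound 1 gives >= 400000 nM, which is a limit of the assay and not a number, as recorded in the limit of >= 400000 nM in this assay, at which 1 of the 3 values shown sits. Two neighbours in the series sit at limits as well. Compound 2 `CCCCCCCCCc1cc2cn(COCCO)c(O)nc-2n1` gives > 80000 nM in this assay, a limit of the assay rather than a measured figure, noted as the limit of > 80000 nM in this assay, at which 1 of the 3 values shown sits. Compound 3 `OCCOCn1cc2ccnc-2nc1O` gives > 400000 nM in this assay, again only a limit, as shown in the limit of > 400000 nM in this assay, at which 1 of the 3 values shown sits. With no numbered value among the three, compound 1 can only be placed at the top edge of what the assay reports, alongside compound 3 and beyond the limit set by compound 2.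

Compound 4 `CCCCCCCCCCc1cc2cn(COCCO)c(=O)nc2o1` differs from compound 1 by butyl in place of hydrogen on a saturated chain carbon, six bonds along the chain from an aromatic carbon. For the measured compounds named here, no pair of measured compounds differing in one place is available, so the size of the step from compound 1 to compound 4 is not known from the data. Since all three measured compounds stop at a limit, the step is expected to be none beyond the scatter, and compound 4 is estimated at 400000 nM, within 100000 nM to 400000 nM, with a number no higher from compound 1 to compound 4 (the limit leaves the size open) expected as the change from compound 1. Whether the assay again reports only a limit for compound 4 remains to be seen.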

Compound 4, minimum cytotoxic concentration: 400000 nM
For compound 4 middle estimate and measured number coincide at the digits printed; low and high end bracket the measured number.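

In this assay compound 4 gives 400000 nM, the only numbered value among the compounds shown, so with butyl in place of hydrogen on a saturated chain carbon, six bonds along the chain from an aromatic carbon, the read-out falls on a figure the assay can report. The reference for this change remains only a limit: the limit of >= 400000 nM in this assay, at which 1 of the 4 values shown sits. The change reads as a number no higher from compound 1 to compound 4 (the limit leaves the size open), so its direction is bounded but its size cannot be read.

On these data alone, whether chain extension at this position lowers the tolerated concentration at all therefore stays open. Also open, as far as these compounds go, is how a still longer chain, or a chain ending in an amine or a carboxylic acid, would read in this assay.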